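Urea series: permeability estimate for compound 3

A few compounds are considered here, and "the series" means these few. Any claim that something is new, unique, unknown or untested is made for them only; others in the source may bear on it.

Two compounds of the shared core have numbers in an ADME assay for permeability, using PAMPA, at pH 7.4; on this read-out higher numbers stand for higher permeability and lower numbers for lower permeability. Compound 1 `Cc1cc(NC(=O)Nc2ncccc2C)c2ccccc2n1` gives 369 10^-6 cm/s, the highest of the two. Compound 2 `Cc1cc(NC(=O)Nc2cccc([N+](=O)[O-])c2)c2ccccc2n1` gives 42 10^-6 cm/s, and the gap between compound 2 and compound 1 lies beyond the scatter. Within the data shown here, no pair of measured compounds differing in a single place is available, so no measured step bears directly on the change considered here.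

Compound 3 `Cc1cc(NC(=O)Nc2ccc(Cl)cc2)c2ccccc2n1` is not yet measured in this assay. It differs from compound 1 by 4-chlorophenyl in place of 3-methylpyridin-2-yl on an amide-type nitrogen. With compound 1 at 369 10^-6 cm/s and compound 2 at 42 10^-6 cm/s bracketing the known range, the step of a 1.8-fold lower number from compound 1 to compound 3 (0.27 log units; within the scatter) is expected to be a moderate drop, possibly no larger than the scatter. Compound 3 is therefore expected at 200 10^-6 cm/s, with a range from 80 10^-6 cm/s to 450 10^-6 cm/s.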

Compound 3, apparent permeability: 537 10^-6 cm/s
For compound 3 the middle estimate is 2.7-fold (0.43 log units) below the measured one; the whole stated range lies below it.
By their numbers in this assay, from the lowest: compound 2; then compounds 1 and 3 (each within the scatter of the next).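

In this assay, among these compounds, this is the first single-place comparison: 4-chlorophenyl in place of 3-methylpyridin-2-yl on an amide-type nitrogen gives a 1.5-fold higher number from compound 1 to compound 3 (0.16 log units; within the scatter) and so leaves the read-out within the scatter. At this position, a carbon-only aromatic ring carrying chlorine and no hydrogen-bond acceptor therefore cannot be told apart from a ring with a hetero atom and a hydrogen-bond acceptor. No supporting data bear on why these two groups read alike here.

From the compounds shown here alone, whether an amine, a carboxylic acid or a longer chain on this amide-type nitrogen would also stay within the scatter remains open. Compound 2 at 42 10^-6 cm/s also remains unconnected to the other compounds by any single-place step.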